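Swapping a methylpyrazole for an acetylpiperidine

The source may hold more compounds than are shown below. What is called first, only, known or untested is meant among the compounds shown, and "the series" means these compounds.

Compound 1 `Cn1cc(-c2cnc(NCc3c(F)ccc4c3CCO4)c3cn[nH]c(=O)c23)cn1` gives 2.7 in a physicochemical assay for lipophilicity, using the shake flask method, in phosphate buffer, measured as octanol-water partition, with a stated time of 30 min, at pH 7.4 (on this read-out lower numbers stand for lower lipophilicity and higher numbers for higher lipophilicity), the highest of the three measured numbers. Compound 3 `CN(C)Cc1ccc2c(c1)CN(c1cnc(NCc3c(F)ccc4c3CCO4)c3cn[nH]c(=O)c13)C2=O` comes nearest with 2.2, a gap beyond the usual scatter, and compound 2 `O=C1CCCN1c1cnc(NCc2c(F)ccc3c2CCO3)n2cnnc12` lies furthest with 1.3, a gap also beyond it. Going by the values given here, no pair of these three differs in only one place, so no single step can be read from them. Compound 4 `CC(=O)N1CCC(c2cnc(NCc3c(F)ccc4c3CCO4)c3cn[nH]c(=O)c23)CC1` has not yet been measured; it differs from compound 1 in one change: 1-acetylpiperidin-4-yl in place of 1-methyl-1H-pyrazol-4-yl on an aromatic carbon. Among the compounds with values here, with no comparable step among the measured compounds, compound 4 is expected to sit slightly lower, a step of a number 0.30 log units lower from compound 1 to compound 4 (within the scatter) that may not exceed the scatter. The estimate for compound 4 in this assay is 2.4, between 1.8 and 3.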

Compound 4, distribution coefficient: 2.9
Compound 4: the middle estimate sits 0.50 log units below what was measured, within the range that was stated.
By their numbers in this assay, from the lowest: compound 2; then compound 3; then compounds 1 and 4 (each within the scatter of the next).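

In this assay, going by these compounds alone, the first step that can be read at this position is a number 0.20 log units higher from compound 1 to compound 4 (within the scatter) for 1-acetylpiperidin-4-yl in place of 1-methyl-1H-pyrazol-4-yl on an aromatic carbon. On this read-out, the two groups cannot be told apart at this place, even though they differ in ring size, aromaticity and heavy-atom count. No evidence is available that bears on this result.

On these data alone, whether a piperidin-4-yl group with a free ring amine would also stay within the scatter of compound 1 remains open. The same holds for a piperidine carrying a carboxylic acid.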